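Nitro in place of methylsulfonyl on the shared core

A few compounds are considered here, and "the series" means these few. Any claim that something is new, unique, unknown or untested is made for them only; others in the source may bear on it.

Compound 1 `Cc1cnc(Nc2ccc(C(C)C)cc2)nc1Nc1nc2ccccc2s1`: > 50000 nM, a limit of the assay rather than a number
Compound 2 `Cc1cnc(Nc2ccc(S(C)(=O)=O)cc2)nc1Nc1nc2ccccc2s1`: 760 nM

Of the compounds shown here, two sharing one core have been measured in a functional assay on HCT-116 cells (Homo sapiens) for antiproliferative activity, read by MTT assay, with a stated time of 48 h; a higher number here means a weaker inhibitor, a lower number a stronger inhibitor. Among the measured compounds shown here, compound 2 gives 760 nM, and this is the only number in this assay. The other value is a limit (the limit of > 50000 nM in this assay, at which 1 of the 2 values shown sits). Compound 1 sits at that limit. For the measured compounds named here, the single measured step runs an at least 65-fold lower number from compound 1 to compound 2 (1.81 log units; beyond the scatter), and the change behind it was methylsulfonyl in place of isopropyl on an aromatic carbon.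

Compound 3 `Cc1cnc(Nc2ccc([N+](=O)[O-])cc2)nc1Nc1nc2ccccc2s1` is not yet measured. It differs from compound 2 by nitro in place of methylsulfonyl on an aromatic carbon. Going by the values given here, the one measured step concerns a different exchange, isopropyl for methylsulfonyl, so it gives no direct guide to swapping methylsulfonyl for nitro; what is shared is that both groups carry two hydrogen-bond acceptors and no donor. The expectation is therefore a step of a 1.3-fold higher number from compound 2 to compound 3 (0.12 log units; within the scatter) that stays within the scatter. Compound 3 is expected to give 1000 nM in this assay, between 250 nM and 4000 nM.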

Compound 3, half-maximal inhibitory concentration: 6330 nM
For compound 3 the middle estimate is 6.3-fold (0.80 log units) below the measured one; measured number above the stated range.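

At this place on the ring, para to a large group, methylsulfonyl and nitro have the same counts of hydrogen-bond donors and acceptors, yet in this assay the exchange gives an 8.3-fold higher number from compound 2 to compound 3 (0.92 log units; beyond the scatter). Matching those counts is therefore not enough to keep the activity, and the two groups cannot be treated as interchangeable here, although they differ by only one heavy atom and one double bond. Nitro in place of isopropyl still gives an at least 7.8-fold lower number from compound 1 to compound 3 (0.89 log units; beyond the scatter), so the gain over isopropyl is not unique to methylsulfonyl, though compound 2 remains clearly ahead of compound 3. Compound 1 gives a limit of the assay rather than a number, so the true size of that step stays unknown: the limit of > 50000 nM in this assay, at which 1 of the 3 values shown sits.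

The compounds shown do not reveal which difference between methylsulfonyl and nitro separates compound 2 from compound 3, as the counts printed for them cannot settle that. Going by these compounds, it also remains open how this place would respond to an amine, a carboxylic acid, an amide or a sulfonamide, any of which would show whether methylsulfonyl is a peak or just one step along a wider trend.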